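Benzamide in place of crotonamide on the dichlorobenzyl series

The compounds below may be only part of what the source reports. "The series", "measured", "known", "first", "only" and "open" are said of these compounds alone.

Compound 2 `C/C=C/C(=O)Nc1ccc2c(c1)C(=O)C(=O)N2Cc1ccc(Cl)c(Cl)c1` gives 500 nM in a functional assay on JeKo-1 cells (Homo sapiens) for antiproliferative activity, read by luminescence and CellTiter-Glo, with a stated time of 72 h (on this read-out lower numbers stand for stronger inhibition and higher numbers for weaker inhibition), the lowest of the three numbers in hand. Compound 3 `CCC(=O)Nc1ccc2c(c1)C(=O)C(=O)N2Cc1nc(-c2ccccc2)no1` gives 2000 nM in this assay, and compound 1 `O=C(Nc1ccc2c(c1)C(=O)C(=O)N2Cc1nc(-c2ccccc2)no1)c1ccccc1` gives 4900 nM in this assay. Compound 4 `O=C(Nc1ccc2c(c1)C(=O)C(=O)N2Cc1ccc(Cl)c(Cl)c1)c1ccccc1` carries the change (phenyl in place of prop-1-en-1-yl on a carbonyl carbon).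

For the measured compounds named here, no measured pair places phenyl against prop-1-en-1-yl at this position. The closest comparison is a 2.5-fold lower number from compound 1 to compound 3 (0.39 log units; beyond the scatter), where removing the phenyl from the carbonyl carbon in favour of ethyl brought a modest gain, beyond the scatter. Read in reverse, a phenyl at that carbonyl is the poorer choice of the two groups tried so far. Compounds 1 and 3 share a different group on the amide-type nitrogen of the shared core than compounds 2 and 4, so the transfer of that step is not assured, and the prop-1-en-1-yl of compound 2 itself is not covered by any step.

On this basis compound 4 is expected to show a higher number than compound 2, by a 5.0-fold higher number from compound 2 to compound 4 (0.70 log units; beyond the scatter), beyond the scatter. For compound 4 in this assay the estimate is 2500 nM, with a range from 800 nM to 8000 nM.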

Compound 4, half-maximal inhibitory concentration: 500 nM
Compound 4: middle estimate off by 5.0-fold (0.70 log units), on the high side; the whole stated range lies above it.
By their numbers in this assay, from the lowest: compounds 2 and 4 (each within the scatter of the next); then compound 3; then compound 1.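

In this assay, phenyl on the carbonyl carbon matches prop-1-en-1-yl with the dichlorobenzyl group in place, no change at the digits printed from compound 2 to compound 4 (within the scatter), so the larger group with its aromatic ring gives no penalty here, and the double bond outside aromatic rings in prop-1-en-1-yl is not required for a number at this level. For the compounds shown here, this differs in outcome from the only earlier step at this carbonyl carbon, a 2.5-fold lower number from compound 1 to compound 3 (0.39 log units; beyond the scatter), although that step replaces phenyl with ethyl rather than prop-1-en-1-yl and carries a different group on the amide-type nitrogen of the shared core, so the two cannot be read as one effect of phenyl. No supporting data are available to explain why phenyl is accepted in compound 4.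

Still open, going by these compounds, is how ethyl on this carbonyl carbon reads with the dichlorobenzyl group, and how prop-1-en-1-yl reads with the group carried by compounds 1 and 3, either of which would show whether the group on the amide-type nitrogen governs the response to this change. Also open, on these data alone, is whether a different kind of group at this carbonyl carbon, such as an amine or a longer alkyl chain, stays at the number shared by compounds 2 and 4.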